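Swapping halogen patterns on the aryl piperazine: compound 3

The source may report more compounds than this note shows. Statements on the series, on what has been measured and on what is new or still open speak of the compounds shown alone.

Measured so far:
- compound 1, `Nc1scc(CN2CCN(c3ccc(F)cc3Cl)CC2)c1C(=O)c1ccc(Cl)cc1`: -70%
- compound 2, `Nc1scc(CN2CCN(c3c(F)cccc3F)CC2)c1C(=O)c1ccc(Cl)cc1`: -80%

Of the compounds shown here, two sharing one core have been tested in a functional assay on CHO cells with adenosine receptor A1 (Homo sapiens) as the target, read by cAMP accumulation and immunoassay, with a stated time of 6 min, tested at 10 uM; on this read-out higher numbers stand for a weaker effect at the one concentration tested and lower numbers for a stronger effect. Compound 1 gives -70%. Compound 2 gives -80%. The only difference between them is the aryl group on the ring nitrogen, and the step of a number 10 percentage points lower from compound 1 to compound 2 (within the scatter) does not separate the two compounds; compound 2 merely sits at one end of the pair, with no claim of order possible.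

Compound 3, `Nc1scc(CN2CCN(c3ccc(F)c(Cl)c3)CC2)c1C(=O)c1ccc(Cl)cc1`, has not yet been measured. Its change from compound 2 is 3-chloro-4-fluorophenyl in place of 2,6-difluorophenyl on an amine nitrogen in a ring. Among the measured compounds shown here, the one measured step that bears on this, a number 10 percentage points lower from compound 1 to compound 2 (within the scatter), also exchanged one halogenated phenyl for another and moved the number only within the scatter. No step beyond the scatter is expected here in this assay, so the estimated step is a number 5 percentage points higher from compound 2 to compound 3 (within the scatter). Compound 3 is therefore expected to give about -75%, with a range from -95% to -50%.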

Compound 3, a percentage reported as activity, at one concentration (the size of the read-out at that concentration, not a potency): -78%
Compound 3: middle estimate off by 3 percentage points, on the high side, within the range that was stated.
By their numbers in this assay, from the lowest: compounds 2, 3 and 1 (each within the scatter of the next).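

In this assay, the 3-chloro-4-fluorophenyl group in place of 2,6-difluorophenyl gives a number 2 percentage points higher from compound 2 to compound 3 (within the scatter), so a third halogen pattern on this phenyl ring can also be accommodated without a step that can be told from the scatter. The new pair that matters most is 2-chloro-4-fluorophenyl and 3-chloro-4-fluorophenyl, which carry the same two halogens and differ only in where the chlorine sits, and that change gives a number 8 percentage points lower from compound 1 to compound 3 (within the scatter) as well. Among these three groups on the amine nitrogen in a ring, then, neither the choice of halogens nor the place of the chlorine separates the compounds on this read-out.

Nothing available here offers an explanation for this lack of separation. From the compounds shown here alone, it remains open whether the number would move beyond the scatter with something other than a halogen on the phenyl ring, such as a methoxy group or a nitrile, or with a plain phenyl carrying no halogen at all.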